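The compounds below may be only part of what the source reports. "The series", "measured", "known", "first", "only" and "open" are said of these compounds alone.

Measured compounds in an in vitro assay on BTI-TN-5B1-4 cells for inhibition of Amine oxidase [flavin-containing] B (Homo sapiens); a higher number here means a weaker inhibitor, a lower number a stronger inhibitor:
- compound 1 `COc1ccc(-c2cc(=O)c3ccc(OC)cc3o2)cc1` gives 49700 nM
- compound 2 `COc1ccc(-c2cc(=S)c3ccc(OC)cc3o2)cc1` gives 3340 nM
- compound 3 `O=C1C[C@H](c2ccc(F)cc2)Oc2cc(F)ccc21` gives 150 nM

Among these three, compound 3 has the lowest number in this assay, and so is the strongest inhibitor of the set: the gap to compound 2, the nearest of the other two, lies beyond the scatter, and the gap to compound 1, the furthest, lies further still. Going by the values given here, compound 1 and compound 2 share a core that differs from that of compound 3, so no single step between measured compounds can be traced.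

Compound 4 `Cc1ccc([C@H]2CC(=O)c3ccc(F)cc3O2)cc1` has not yet been measured in this assay. It is reached from compound 3 by one change: methyl in place of fluoro on an aromatic carbon. Both groups are small, neither donates nor accepts a hydrogen bond, and the place on the ring is the same.

Among the compounds with values here, no measured pair shows this change, so the step is guessed rather than read off. On the pattern of compound 3, the author expects the step of a 1.4-fold lower number from compound 3 to compound 4 (0.13 log units; within the scatter) to stay close to the scatter, with no strong lean either way. For compound 4 the estimate in this assay is 110 nM, within a range from 30 nM to 400 nM.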

Compound 4, half-maximal inhibitory concentration: 150 nM
The estimate for compound 4 lay 1.4-fold (0.13 log units) below the measured number; low and high end bracket the measured number.
By their numbers in this assay, from the lowest: compounds 3 and 4 (each within the scatter of the next); then compound 2; then compound 1.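

In this assay, methyl in place of fluoro on an aromatic carbon, para to a large group, gives no change at the digits printed from compound 3 to compound 4 (within the scatter). Going by these compounds alone, this is the only step in the set that can be read in one place, and the earlier compounds offered no such comparison. It shows that, at this place on the six-membered aromatic ring, this assay does not tell these two groups apart, at least on this core and with the remaining fluoro of compound 4 left in place. No measurement shown here speaks to what lies behind this result.

The compounds shown leave open whether a group of another kind at the same place, such as an amine, a carboxylic acid, a methoxy group or a longer chain, would also stay within the scatter of compound 3. They also leave open whether the same change would read alike at the remaining fluoro of compound 4, and steps linking compound 1 or compound 2 to compound 3 or compound 4 cannot be read, as those compounds differ in more than one place.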